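This account rests on a few compounds, and the source may have more. Where it says the series, first, only, none or still open, it means among the compounds named here.

Measured so far:
compound 1 `O=C(Nc1ccccc1)Nc1cccc(CNc2nccnc2Cl)c1` — 19800 nM in a functional assay on T-24 cells (Homo sapiens) for antiproliferative activity, read by MTT assay, with a stated time of 48 h; a lower number here means a stronger inhibitor, a higher number a weaker inhibitor.
compound 2 `O=C(Nc1cccc(CNc2nccnc2Cl)c1)NC1CCCCC1` — > 40000 nM.
compound 3 `CCc1ccc(NC(=O)Nc2cccc(CNc3nccnc3Cl)c2)c(CC)c1` — 6390 nM.

Compound 2 has in this assay only a limit, not a number: it sits at the limit of > 40000 nM in this assay, at which 1 of the 3 values shown sits. Compound 1 gives a real number, 19800 nM, and compound 3, which carries 2,4-diethylphenyl at the urea nitrogen, gives 6390 nM.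

Compound 4 `O=C(Nc1cccc(CNc2nccnc2Cl)c1)Nc1ccc(Cl)cc1Cl` differs from compound 2 by 2,4-dichlorophenyl in place of cyclohexyl on an amide-type nitrogen. Within the data shown here, one measured step bears directly on this position, and it runs the other way: an at least 2.0-fold higher number from compound 1 to compound 2 (0.30 log units; that floor lies within the scatter), where cyclohexyl replaced phenyl and the number went from a measured value up to the limit. Going back from cyclohexyl to an aromatic ring is therefore expected to lower the number again, by at least as much as that step, with the understanding that the floor of that step lies within the scatter. Among the measured compounds shown here, no measured step connects a plain phenyl with a 2,4-disubstituted phenyl, so what compound 1 and compound 3 show can only be read as two separate values.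

The step from compound 2 to compound 4 is expected to be an at least 5.0-fold lower number from compound 2 to compound 4 (0.69 log units; beyond the scatter), toward a stronger inhibitor. For compound 4 the estimate in this assay is 8000 nM, with a range from 3000 nM to 25000 nM.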

Compound 4, half-maximal inhibitory concentration: 5740 nM
Estimate against measurement, compound 4: 1.4-fold (0.14 log units) above, within the range that was stated.
By their numbers in this assay, from the lowest: compounds 4 and 3 (each within the scatter of the next); then compound 1. At a limit, above all of these: compound 2.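

Compound 2 has only a limit in this assay, so the change on this nitrogen from cyclohexyl to an aromatic ring can be read only as a floor: the limit of > 40000 nM in this assay, at which 1 of the 4 values shown sits.

That floor now stands at an at least 6.9-fold lower number from compound 2 to compound 4 (0.84 log units; beyond the scatter), while the earlier at least 2.0-fold higher number from compound 1 to compound 2 (0.30 log units; that floor lies within the scatter) left it within the scatter, so the difference between cyclohexyl and an aromatic ring at this place is now readable. The change also has a measured step within the aromatic series, a 3.4-fold lower number from compound 1 to compound 4 (0.54 log units; beyond the scatter), which places 2,4-dichlorophenyl clearly apart from plain phenyl, and compound 4 lies within the scatter of compound 3, which carries 2,4-diethylphenyl.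

Open, on these data alone, is whether a phenyl with a single chlorine, a methoxyphenyl or a pyridyl ring on this nitrogen would give the same lowering as 2,4-dichlorophenyl. Also open, as far as these compounds go, is whether a benzyl group or a small alkyl such as methyl in place of cyclohexyl would stay at the limit, and how much of any of these numbers depends on the chlorine of the shared core.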